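This account rests on a few compounds, and the source may have more. Where it says the series, first, only, none or still open, it means among the compounds named here.

In a functional assay on HCT-8 cells (Homo sapiens) for antiproliferative activity, read by MTT assay, with a stated time of 48 h (on this read-out higher numbers stand for weaker inhibition and lower numbers for stronger inhibition), three compounds have been measured so far. Compound 1, `COc1ccc2c(/C=C/C(=O)c3cc(OC)c(OC)c([N+](=O)[O-])c3)c[nH]c2c1`, gives 982 nM. Compound 2, `COc1cc(C(=O)/C=C/c2c[nH]c3ccccc23)cc([N+](=O)[O-])c1OC`, gives 1390 nM. Compound 3, `COc1ccc2c(/C=C(\C)C(=O)c3cc(OC)c(OC)c([Se]C)c3)c[nH]c2c1`, gives 29 nM.

Compound 4, `COc1cc(C(=O)/C(C)=C/c2c[nH]c3ccccc23)cc([Se]C)c1OC`, is still to be measured. It is made from compound 3 by one change, (hydrogen in place of methoxy on an aromatic carbon). The same change has been made once before, from compound 1 to compound 2, where it reads (hydrogen in place of methoxy on an aromatic carbon); the two descriptions agree word for word, so this is the same change at the same place. That earlier step gave a 1.4-fold higher number from compound 1 to compound 2 (0.15 log units; within the scatter), a difference too small to count as a real shift.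

How the core of compound 3 differs from the core of compound 1 is not broken down here; what the values show is that compound 3 has the lowest number of the three, with its gaps to compound 1 and compound 2 both beyond the usual scatter.

For compound 4 a step of the same small size is expected, a 1.4-fold higher number from compound 3 to compound 4 (0.14 log units; within the scatter), because the identical change earlier gave a 1.4-fold higher number from compound 1 to compound 2 (0.15 log units; within the scatter). Compound 4 is therefore estimated at 40 nM, most likely between 15 nM and 110 nM.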

Compound 4, half-maximal inhibitory concentration: 32 nM
The estimate for compound 4 lay 1.3-fold (0.10 log units) above the measured number; low and high end bracket the measured number.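

In this assay, replacing the methoxy on the aromatic carbon with hydrogen gives a 1.1-fold higher number from compound 3 to compound 4 (0.04 log units; within the scatter), so on this core too the methoxy can go without a shift that stands out from the usual spread of repeat measurements. Set beside the earlier step, the change carries over from one core to the other with no real difference in its size: the same change on two cores in this assay, a 1.4-fold higher number (0.15 log units; within the scatter) from compound 1 to compound 2 and a 1.1-fold higher number (0.04 log units; within the scatter) from compound 3 to compound 4, 1.3-fold (0.11 log units) apart, within the scatter of two such steps This shows that the result held on both cores in this cell assay, but two pairs do not make a rule for other cores, and these numbers do not show why the change makes so little difference.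

What the compounds shown leave open is whether a group other than methoxy or hydrogen at this same carbon, such as a hydroxyl, an amine or a longer alkoxy chain, would also leave the number in place. Also open is how the other parts of the two cores each contribute, since no pair shown differs in just one of those places.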